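Trading a fluoropiperidine for a ring with one double bond

A few compounds are considered here, and "the series" means these few. Any claim that something is new, unique, unknown or untested is made for them only; others in the source may bear on it.

Measured so far in an assay on CHO-K1 cells for antagonist activity at adenosine receptor A1 (Homo sapiens), read by a beta-galactosidase reporter, with stated times of 15 min and 6 h; on this read-out higher numbers stand for weaker inhibition and lower numbers for stronger inhibition:
compound 1 `Nc1nc(-c2ccco2)nc2sc(CN3CC=CCC3)cc12` gives 150 nM
compound 2 `Nc1nc(-c2ccco2)nc2sc(CN3CCC(F)CC3)cc12` gives 740 nM
compound 3 `Nc1nc(-c2ccc(Cl)o2)nc2sc(CN3CCC(F)CC3)cc12` gives 1080 nM

All three compounds share one core and differ at two places. Compound 2 and compound 3 differ only at the five-membered ring: chloro in place of hydrogen on an aromatic carbon. This gives a 1.5-fold higher number from compound 2 to compound 3 (0.16 log units; within the scatter), so the two values cannot be told apart. Compound 1 and compound 2 differ only at the ring hanging from the chain: a group of 6 heavy atoms (5 carbon, 1 nitrogen; one six-membered non-aromatic ring with 1 hetero atom) in place of a group of 7 heavy atoms (5 carbon, 1 nitrogen, 1 fluorine; one six-membered non-aromatic ring with 1 hetero atom), on a saturated chain carbon bound to an aromatic carbon. Here the effect is clearer, a 4.9-fold lower number from compound 2 to compound 1 (0.69 log units; beyond the scatter), a step that stands out from the noise of repeated measurement.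

Compound 4 `Nc1nc(-c2ccc(Cl)o2)nc2sc(CN3CC=CCC3)cc12` has not yet been measured. Relative to compound 3 it carries the change (a group of 6 heavy atoms (5 carbon, 1 nitrogen; one six-membered non-aromatic ring with 1 hetero atom) in place of a group of 7 heavy atoms (5 carbon, 1 nitrogen, 1 fluorine; one six-membered non-aromatic ring with 1 hetero atom), on a saturated chain carbon bound to an aromatic carbon), at the same place as the change from compound 2 to compound 1, so this is the same change made on the chloro-bearing core. Among the measured compounds shown here, the expectation for compound 4 rests on a single earlier instance of that change, because a 4.9-fold lower number from compound 2 to compound 1 (0.69 log units; beyond the scatter) is the only step of this kind measured here. The step expected in this assay is a 4.9-fold lower number from compound 3 to compound 4 (0.69 log units; beyond the scatter), of roughly the size seen before. On that basis compound 4 is estimated at 220 nM, with a likely range from 110 nM to 450 nM.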

Compound 4, inhibition constant: 190 nM
Compound 4: middle estimate off by 1.2-fold (0.06 log units), on the high side; measured number inside the range.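

In this assay, putting the ring with one double bond in place of the 4-fluoropiperidin-1-yl group on the chloro-bearing core gives a 5.7-fold lower number from compound 3 to compound 4 (0.75 log units; beyond the scatter) and so repeats what the same swap did on the core without chloro: the same change on two cores in this assay, a 4.9-fold lower number (0.69 log units; beyond the scatter) from compound 2 to compound 1 and a 5.7-fold lower number (0.75 log units; beyond the scatter) from compound 3 to compound 4, 1.2-fold (0.06 log units) apart, within the scatter of two such steps.

Chloro in place of hydrogen on the five-membered ring gives a 1.3-fold higher number from compound 1 to compound 4 (0.10 log units; within the scatter) and leaves the two compounds impossible to tell apart, so this second change also reads the same on both backgrounds: the same change on two cores in this assay, a 1.5-fold higher number (0.16 log units; within the scatter) from compound 2 to compound 3 and a 1.3-fold higher number (0.10 log units; within the scatter) from compound 1 to compound 4, 1.2-fold (0.06 log units) apart, within the scatter of two such steps.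

Together these two results show that, for these four compounds, the two changes behave independently, with the ring swap accounting for the clear step and the chloro for none that can be read; they do not show that this would hold on any other core or in any other assay, and they say nothing about why the swap has this effect.

The swap removes the fluorine and adds the double bond in one move, so a plain piperidine ring with neither feature would be needed to tell which of the two matters. Also open, on these data alone, is how other amines, such as morpholine or pyrrolidine, would behave on this chain, and whether a bromo or methyl group on the five-membered ring would read the same as chloro.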